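Swapping Tert-Butyl for Trifluoromethyl: An Expected Read-Out

The source may hold more compounds than are shown below. What is called first, only, known or untested is meant among the compounds shown, and "the series" means these compounds.

Measured compounds:
compound 1, `Cc1ccccc1NC(=O)N[C@@H](C)c1ccccc1`, gives 99%
compound 2, `CCc1ccccc1NC(=O)N[C@@H](C)c1ccccc1`, gives 95%
compound 3, `C[C@H](NC(=O)Nc1ccccc1C(C)(C)C)c1ccccc1`, gives 100%

These three compounds share a core and differ only in the group sitting on one aromatic carbon or in a chain carbon bound to an aromatic carbon. All were tested in an ADME assay on the whole organism with Oryza sativa as the target, tested at 10 uM; a lower number here means a stronger effect, a higher number a weaker effect of the compound at the concentration tested. The numbers of compound 3 sit together with those of compound 1 and compound 2: the change a number 1 percentage points higher from compound 1 to compound 3 (within the scatter) and the change a number 5 percentage points higher from compound 2 to compound 3 (within the scatter) are both small, and the same holds for a number 4 percentage points lower from compound 1 to compound 2 (within the scatter). No measured value stands apart from the others.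

Compound 4, `C[C@H](NC(=O)Nc1ccccc1C(F)(F)F)c1ccccc1`, has not been measured. It differs from compound 3 as follows: trifluoromethyl in place of tert-butyl on an aromatic carbon. Going by the values given here, no measured pair introduces a trifluoromethyl, so there is no direct step to lean on. The steps that touch the same aromatic carbon, methyl to tert-butyl and ethyl to tert-butyl, stayed within the scatter, and so the step for compound 4 in this assay is expected to be small, without a clear direction.

Compound 4 is therefore expected to give about 97%, within a range from 87% to 100%, which means a step of a number 3 percentage points lower from compound 3 to compound 4 (within the scatter) is estimated.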

Compound 4, a percentage reported as activity, at one concentration (the size of the read-out at that concentration, not a potency): 97%
Beside the measured number, compound 4's estimate shows no gap at the digits printed; the measured number falls inside the stated range.
By their numbers in this assay, from the lowest: compounds 2, 4, 1 and 3 (each within the scatter of the next).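

In this assay trifluoromethyl on this aromatic carbon cannot be told apart from the three alkyl groups, as all three new steps show (a number 3 percentage points lower from compound 3 to compound 4 (within the scatter); a number 2 percentage points higher from compound 2 to compound 4 (within the scatter); a number 2 percentage points lower from compound 1 to compound 4 (within the scatter)). The earlier compounds shown here carried only groups built from carbon and hydrogen here, whereas compound 4 shows that a group with fluorine in place of the three outer carbons of tert-butyl, and with the same heavy-atom count, also gives a read-out within the scatter of the others. Nothing at hand explains this outcome.

The compounds shown therefore leave open whether any group at this place can shift the read-out beyond the scatter, since all four groups sit on the same aromatic carbon and none of their steps separates them. An amine, a carboxylic acid or a longer chain on this carbon would test that question, and so would trifluoromethyl on another carbon of the same ring.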